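A few compounds are considered here, and "the series" means these few. Any claim that something is new, unique, unknown or untested is made for them only; others in the source may bear on it.

Measured compounds:
- compound 1 `CC(C)c1c(OC2CCCCC2C)cc(Cc2ccc(Cl)cc2)[nH]c1=O` gives 84000 nM in an ADME assay on MT4 cells (Homo sapiens) for cytotoxicity, read by XTT assay, with a stated time of 3 days; on this read-out lower numbers stand for higher toxicity in this test and higher numbers for lower toxicity in this test
- compound 2 `CC(C)c1c(O[C@H]2CCCC[C@@H]2C)cc(CCc2ccccc2)[nH]c1=O` gives > 300000 nM in this assay

Of the compounds shown here, two sharing the same core have been tested for how strongly they harm cultured human cells. In this assay compound 1 gives 84000 nM. Among the compounds with values here, for compound 2 the result is only a limit of the test, > 300000 nM, so no number is known, only that the true value lies past the end of the measured range. Within the data shown here, since the two compounds differ in more than one place, no single step between them is counted; their values simply show that compound 2 sits at the limit of > 300000 nM in this assay, at which 1 of the 2 values shown sits, while compound 1 sits well inside the measured range.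

Compound 3 `CC(C)c1c(OC2CCCCC2C)cc(CCc2ccccc2)[nH]c1=O` has not yet been tested. It differs from compound 2 only in how its stereochemistry is drawn: the two compounds have the same atoms and bonds; at least one stereo element is drawn with a configuration in one of them and without one in the other: 2 of 2 stereo elements differ; a stereocentre at a saturated ring carbon is drawn S in compound 2 and without a configuration in compound 3; a stereocentre at a saturated ring carbon is drawn S in compound 2 and without a configuration in compound 3. The atoms and bonds are the same, so compound 3 is a mixture that contains compound 2 itself. No change beyond the usual scatter is expected in this assay, so the step of an at least 1.2-fold lower number from compound 2 to compound 3 (0.07 log units; that floor lies within the scatter) is estimated to be essentially flat. Compound 3 is therefore expected to give about 250000 nM, within a range of 100000 nM to 600000 nM.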

Compound 3, half-maximal cytotoxic concentration: 201000 nM
The estimate for compound 3 lay 1.2-fold (0.09 log units) above the measured number; measured number inside the range.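

In this assay, within the data shown here, benzyl in place of 4-chlorophenyl on a saturated chain carbon bound to an aromatic carbon gives a 2.4-fold higher number from compound 1 to compound 3 (0.38 log units; beyond the scatter), the first step at this position that can be read beyond the scatter, and it is a modest move toward lower toxicity in this test. The change in how the stereochemistry is drawn gives an at least 1.4-fold lower number from compound 2 to compound 3 (0.17 log units; that floor lies within the scatter), which shows no shift that stands clear of the scatter. Compound 2 remains a limit of the test, so that step is only a floor, and it cannot be tied to one spatial form of the ring because of one point: the fact that one of compounds 2 and 3 is drawn with a defined configuration and the other without, at the place where they differ

The step from benzyl to 4-chlorophenyl changes the group as a whole, so the compounds shown do not separate what the chlorine contributes from what the rest of the group contributes, and they do not show how the other spatial forms of the ring would read on their own. On these data alone, how an amine, a carboxylic acid or a longer chain in place of benzyl would read in this assay also stays open.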